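Adding a Second Chloro Group to Two Related Cores

A few compounds are considered here, and "the series" means these few. Any claim that something is new, unique, unknown or untested is made for them only; others in the source may bear on it.

Of the compounds shown here, three have been tested in a functional assay on OVCAR-3 cells (Homo sapiens) for cytotoxicity, read by sulforhodamine B assay, with a stated time of 48 h; a higher number here means a weaker inhibitor of growth, a lower number a stronger inhibitor of growth. Compound 1 `ClCc1ccccc1Cn1cnc2c(Cl)nc(Cl)nc21` gives 210 nM in this assay. Compound 2 `ClCc1ccccc1Cn1cnc2c(Cl)ncnc21`, which carries one chloro group fewer, gives 1410 nM in this assay. Compound 3 `ClCc1ccccc1Cn1cnc2ncnc(Cl)c21` gives 2040 nM in this assay, the highest of the three numbers, though its gap to compound 2 is within the scatter, so these two cannot be ranked against each other. Compound 1 stands apart from both.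

Going by the values given here, the only change within a pair of measured compounds is chloro in place of hydrogen on an aromatic carbon, and that step, a 6.7-fold lower number from compound 2 to compound 1 (0.83 log units; beyond the scatter), is modest but beyond the scatter. Compounds 2 and 3 share the same atoms joined differently; the difference between the two cores is not broken down here.

Compound 4 `ClCc1ccccc1Cn1cnc2nc(Cl)nc(Cl)c21` has not yet been measured. Among the compounds with values here, it arises from compound 3 through (chloro in place of hydrogen on an aromatic carbon), which is the same change, at a place described in the same words, as the one from compound 2 to compound 1. Because compound 2 to compound 1 gave a 6.7-fold lower number from compound 2 to compound 1 (0.83 log units; beyond the scatter), the step for compound 4 is expected to run in the same direction, a 5.1-fold lower number from compound 3 to compound 4 (0.71 log units; beyond the scatter), though with a single precedent on a different core the size is uncertain. The value of compound 4 in this assay is estimated at 400 nM, expected to lie between 150 nM and 1100 nM.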

Compound 4, concentration for 50% growth inhibition: 14100 nM
Estimate against measurement, compound 4: 35-fold (1.55 log units) below; the whole stated range lies below it.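

The new step in this assay is a 6.9-fold higher number from compound 3 to compound 4 (0.84 log units; beyond the scatter), so the chloro group that went with stronger growth inhibition on one core went with weaker growth inhibition on the other. Set side by side, the same change, described in the same words, ran in opposite directions on the two cores, and the gap between the two steps is larger than repeated measurement would explain: the same change on two cores in this assay, a 6.7-fold lower number (0.83 log units; beyond the scatter) from compound 2 to compound 1 and a 6.9-fold higher number (0.84 log units; beyond the scatter) from compound 3 to compound 4, 46-fold (1.67 log units) apart, beyond the scatter of two such steps This shows that in this series the effect of adding this chloro group cannot simply be carried from one core to the other, although it rests on a single pair of steps and does not show why the two cores part ways or how the change would behave on any further core.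

The compounds shown leave open whether a different group on that aromatic carbon between two ring nitrogen atoms, such as an amine or a methoxy group, would also pull the two cores in opposite directions. They also leave open whether the two cores would still differ in this way if the chloromethyl group shared by all four compounds were replaced by a hydroxymethyl group.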